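Compound 1 to compound 3: bromo for chloro

The source may hold more compounds than are shown below. What is called first, only, known or untested is meant among the compounds shown, and "the series" means these compounds.

In a physicochemical assay for solubility (a lower number here means a less soluble compound, a higher number a more soluble compound), compound 1 `O=C(Nc1ccc([N+](=O)[O-])c(Cl)c1)c1cc(Cl)ccc1O` reads < 1 ug/mL, which is a limit of the assay and not a number. Compound 2 `O=C(Nc1ccc(F)c(Cl)c1)c1cc(Cl)ccc1O` gives 2.4 ug/mL. Compound 3 `O=C(Nc1ccc([N+](=O)[O-])c(Cl)c1)c1cc(Br)ccc1O` carries bromo in place of chloro on an aromatic carbon, para to a hydroxy group (bromo in place of chloro on an aromatic carbon). For the measured compounds named here, the only measured step, an at least 2.4-fold higher number from compound 1 to compound 2 (0.38 log units; beyond the scatter), is fluoro in place of nitro, a different change that gives no direct size for this one. No step beyond the scatter is therefore expected in this assay. The expected step is a step that the limit leaves unreadable from compound 1 to compound 3. Compound 3 is expected at 0.7 ug/mL, with an estimated range of 0.3 ug/mL to 1.5 ug/mL.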

Compound 3, solubility: < 1 ug/mL
Compound 3 gave a limit, no number (the forecaster's own chance of this, stated with the estimate: 70%); the middle value is on the limit's open side.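

No step can be read from compound 1 to compound 3 in this assay, because both compounds give a limit and not a number: the limit of < 1 ug/mL in this assay, at which 2 of the 3 values shown sit.

As far as these compounds go, whether bromo in place of chloro shifts the read-out at all, and in which direction, stays open.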